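This account rests on a few compounds, and the source may have more. Where it says the series, first, only, none or still open, it means among the compounds named here.

In a functional assay on ACHN cells (Homo sapiens) (on this read-out higher numbers stand for weaker inhibition of growth and lower numbers for stronger inhibition of growth), compound 1 `O=S(=O)(/C=C/c1ccc(F)cc1)Cc1ccc(Nc2ncnc3ccccc23)cc1` gives 10 nM. Compound 3 `O=S(=O)(/C=C/c1ccc(Cl)cc1)Cc1ccc(Nc2ncnc3ccccc23)cc1` gives > 100000 nM, which is a limit of the assay and not a number. Compound 3 therefore sits at the limit of > 100000 nM in this assay, at which 2 of the 3 values shown sit. Compound 4 `O=S(=O)(/C=C/c1ccc(O)cc1)Cc1ccc(Nc2ncnc3ccccc23)cc1` changes one place in compound 3: hydroxy in place of chloro on an aromatic carbon. This is hydroxy in place of chloro on an aromatic carbon, para to a large group.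

For the measured compounds named here, one measured step touches this same place. Chloro in place of fluoro on an aromatic carbon gave an at least 10000-fold higher number from compound 1 to compound 3 (4.00 log units; beyond the scatter), which shows that a single swap here can move the number very far. Going by the values given here, that step involves a different pair of groups, however, and no measured compound carries hydroxy as the only change. Compound 2 `CC(C)(C)c1cc(/C=C/S(=O)(=O)Cc2ccc(Nc3ncnc4ccccc34)cc2)cc(C(C)(C)C)c1O` also has a hydroxy on its aromatic ring, alongside other groups, and its value of > 100000 nM is likewise a limit. Compound 4 may therefore stay at the limit too.

Starting from a limit, any measurable change can only be toward a lower number, meaning stronger inhibition of growth. The expected move is an at least 33-fold lower number from compound 3 to compound 4 (1.52 log units; beyond the scatter), an estimate that carries wide uncertainty. For compound 4 the estimated value is 3000 nM, with an expected range from 50 nM to 100000 nM.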

Compound 4, concentration for 50% growth inhibition: 20 nM
The estimate for compound 4 lay 150-fold (2.18 log units) above the measured number; the whole stated range lies above it.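

In this assay, hydroxy in place of chloro on the aromatic carbon gives an at least 5000-fold lower number from compound 3 to compound 4 (3.69 log units; beyond the scatter), so the large shift at this place runs in both directions and does not depend on fluoro alone. Hydroxy and fluoro cannot be told apart here, since the comparison gives a 2.0-fold higher number from compound 1 to compound 4 (0.30 log units; within the scatter), which lies within the usual scatter; among compound 1, compound 3 and compound 4, which differ only at this place, chloro is therefore the one group that stands apart. Compound 3 remains a limit of the assay and not a number, so the true size of both steps that start or end there stays unknown, and it shares that kind of value with one other compound: the limit of > 100000 nM in this assay, at which 2 of the 4 values shown sit.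

The compounds shown leave open whether the result with chloro belongs to that group alone or would recur with bromo, methyl or methoxy, and where an amine or a carboxylic acid would fall at the same place. They also leave open whether fluoro, chloro and hydroxy would keep this pattern on another carbon of the same ring.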